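The source may report more compounds than this note shows. Statements on the series, on what has been measured and on what is new or still open speak of the compounds shown alone.

Compound 2 `COc1ccc(C2CC(c3ccccc3)=NN2c2nc(-c3ccccc3)c(C#N)c(=O)n2C)cc1` gives 18000 nM in a functional assay on MCF7 cells (Homo sapiens) for antiproliferative activity, with a stated time of 72 h (a lower number here means a stronger inhibitor, a higher number a weaker inhibitor), the higher of the two numbers recorded. Compound 1 `Cn1c(N2N=C(c3ccccc3)CC2c2ccc(Cl)cc2)nc(-c2ccccc2)c(C#N)c1=O` gives 3280 nM in this assay. Going by the values given here, the one measured step that bears on the question is a 5.5-fold higher number from compound 1 to compound 2 (0.74 log units; beyond the scatter), a methoxy in place of chloro on an aromatic carbon. Compound 3 `Cn1c(N2N=C(c3ccccc3)CC2c2ccc(F)cc2)nc(-c2ccccc2)c(C#N)c1=O` differs from compound 2 by fluoro in place of methoxy on an aromatic carbon. Fluoro, like chloro, is a halogen, so the move is expected to undo part of the change seen in a 5.5-fold higher number from compound 1 to compound 2 (0.74 log units; beyond the scatter), though no fluoro compound has been measured yet. The expected step is a 3.3-fold lower number from compound 2 to compound 3 (0.51 log units; beyond the scatter). Compound 3 is therefore estimated at 5500 nM, with a range of 2200 nM to 14000 nM.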

Compound 3, half-maximal inhibitory concentration: 38100 nM
Compound 3: middle estimate off by 6.9-fold (0.84 log units), on the low side; measured number outside the range, above it.
By their numbers in this assay, from the lowest: compound 1; then compound 2; then compound 3.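

In this assay, the two halogens at this position do not behave alike: fluoro in place of chloro gives a 12-fold higher number from compound 1 to compound 3 (1.07 log units; beyond the scatter). Fluoro in place of methoxy gives a 2.1-fold higher number from compound 2 to compound 3 (0.33 log units; beyond the scatter), so methoxy falls between the two halogens and halogen identity, not halogen presence, tracks with the order across these three compounds. No evidence here bears on the reason for this order. From the compounds shown here alone, how bromo, methyl or an amine on this aromatic carbon would rank remains open. Going by these compounds, whether the order carries over to other substituents elsewhere on the shared core also remains open.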